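The source may report more compounds than this note shows. Statements on the series, on what has been measured and on what is new or still open speak of the compounds shown alone.

Measured compounds:
- Compound 1, `CC#C[C@H]1CN(S(=O)(=O)c2ccc(N)nc2)CCN1c1ccccc1`: in an ADME assay (liver) for metabolic stability, with Liver microsome (Rattus norvegicus) as the target, using microsomes and NADPH, with a stated time of 30 min (on this read-out higher numbers stand for fast clearance and lower numbers for slow clearance), compound 1 gives > 399 mL.min-1.g-1, which is a limit of the assay and not a number.
- Compound 2, `CC#C[C@H]1CN(S(=O)(=O)c2ccc(N)nc2)CCN1c1ccc(S(=O)(=O)Nc2ccccc2)cc1`: in this assay compound 2 gives > 399 mL.min-1.g-1, again a limit rather than a number.

For the measured compounds named here, compound 1 therefore stands only at a limit of this assay, and the single comparison available to it is a step that the two limits leave unreadable from compound 1 to compound 2, which is also unreadable, with both values sitting at the limit (the limit of > 399 mL.min-1.g-1 in this assay, at which 2 of the 2 values shown sit). The change that adds a phenylsulfamoyl group on an aromatic carbon thus tells nothing about the size or direction of any step.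

Compound 3, `CC#C[C@H]1CN(S(=O)(=O)c2ccc(N)nc2)CCN1c1ccc(S(C)(=N)=O)cc1`, differs from compound 1 by a group of 4 heavy atoms (1 carbon, 1 nitrogen, 1 oxygen, 1 sulfur; no ring) in place of a hydrogen atom, on an aromatic carbon. Going by the values given here, no measured step bears on this change with a readable size, so no shift beyond the usual scatter can be predicted in this assay; the one neighbouring pair is only a pair of limits. The step from compound 1 to compound 3 is expected to be an at least 1.1-fold lower number from compound 1 to compound 3 (0.05 log units; that floor lies within the scatter), meaning no readable change. Compound 3 is therefore estimated at 350 mL.min-1.g-1, within a range from 120 mL.min-1.g-1 to 900 mL.min-1.g-1, most likely reported as a limit again.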

Compound 3, intrinsic clearance in microsomes: < 14 mL.min-1.g-1
Compound 3: no number, only a limit; the forecaster's own chance of this, stated with the estimate: 60%; at least 25-fold (1.39 log units) between middle value and limit.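

Placing the group of 4 heavy atoms on the aromatic carbon, in place of a hydrogen atom, gives an at least 28-fold lower number from compound 1 to compound 3 (1.45 log units; beyond the scatter) in this assay, so a change at this place on the ring can move the read-out by a large amount, which the unreadable pair of compound 1 and compound 2 could not reveal. Using the same group in place of phenylsulfamoyl gives an at least 28-fold lower number from compound 2 to compound 3 (1.45 log units; beyond the scatter), so the two groups at this place are clearly not interchangeable, with the group of 4 heavy atoms on the slow-clearance side. These steps are minimum sizes and not exact ones, as compound 3 stands at a limit of the assay rather than at a number: the limit of < 14 mL.min-1.g-1 in this assay, at which 1 of the 3 values shown sits.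

From the compounds shown here alone, the actual clearance of compound 3 remains unknown, as do the actual clearances of compound 1 and compound 2. Going by these compounds, it also remains open whether only the group of 4 heavy atoms gives such a low reading, since these compounds do not show how an amine, a carboxylic acid or a longer carbon chain would read at the same place.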